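A few compounds are considered here, and "the series" means these few. Any claim that something is new, unique, unknown or untested is made for them only; others in the source may bear on it.

Working notes on the series in a functional assay on TK-10 cells (Homo sapiens) for inhibition, read by sulforhodamine B assay, with a stated time of 48 h; on this read-out lower numbers stand for stronger inhibition of growth and higher numbers for weaker inhibition of growth. Compound 1 `O=C(Nc1cccc(-n2cc(-c3ccncc3)c(-c3ccc(Cl)c(O)c3)n2)c1)Nc1ccc(Cl)c(Cl)c1` gives 1910 nM. Compound 2 `COc1cc(-c2nn(-c3cccc(NC(=O)c4cccc(C(F)(F)F)c4)c3)cc2-c2ccncc2)ccc1Cl` gives 3240 nM. Among the compounds with values here, compound 2 has the higher of the two numbers so far, but the gap to compound 1 lies within the scatter, so the two compounds read as equivalent on this read-out. Compound 3 `COc1cc(-c2nn(-c3cccc(NC(=O)Nc4ccc(Cl)c(C(F)(F)F)c4)c3)cc2-c2ccncc2)ccc1Cl` is not yet measured in this assay. It differs from compound 2 in one place: (4-chloro-3-(trifluoromethyl)phenyl)amino in place of 3-(trifluoromethyl)phenyl on a carbonyl carbon. The rest of compound 2 is kept unchanged. Within the data shown here, no step between measured compounds is available, so no measured size of change guides the expectation, and the difference in this assay between compound 1 and compound 2 is itself within the scatter. Because compound 1 gives 1910 nM and shares with compound 3 the amino link on the carbonyl carbon, compound 3 is expected to fall near the two measured values rather than away from them. The step from compound 2 to compound 3 is expected to be a 1.7-fold lower number from compound 2 to compound 3 (0.23 log units; within the scatter), a small change within the scatter. The estimate for compound 3 in this assay is 1900 nM, with a range from 600 nM to 6000 nM.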

Compound 3, concentration for 50% growth inhibition: 1520 nM
Beside the measured number, compound 3's estimate is 1.3-fold (0.10 log units) above it; measured number inside the range.
By their numbers in this assay, from the lowest: compounds 3, 1 and 2 (each within the scatter of the next, the first and the last beyond it).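

Within the data shown here, on a carbonyl carbon whose other neighbour is an amide-type nitrogen, the replacement of 3-(trifluoromethyl)phenyl by (4-chloro-3-(trifluoromethyl)phenyl)amino gives in this assay a 2.1-fold lower number from compound 2 to compound 3 (0.33 log units; beyond the scatter) and so supplies the only measured size of change at one place, a modest one that lies beyond the scatter. The replacement brings in two features together, the chlorine on the aromatic ring and the amino link with its hydrogen-bond donor, while the trifluoromethyl group and the rest of compound 2 stay in place, so the step belongs to the pair and not to either feature alone. Nothing available explains why the number moves with this change.

The compounds shown leave open whether the amino link or the chlorine accounts for the step, a question that a compound carrying only one of the two would settle. Also open, from the compounds shown here alone, is how the number responds at this place to other groups, such as a methylene link in place of the amino link or a carboxylic acid in place of the chlorine.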